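A few compounds are considered here, and "the series" means these few. Any claim that something is new, unique, unknown or untested is made for them only; others in the source may bear on it.

In a functional assay on HL-60 cells (Homo sapiens) for cytotoxicity, read by WST assay, with a stated time of 48 h (a higher number here means that more compound is needed for the effect, a lower number that less compound is needed), three compounds sharing one core have been measured. Compound 1 `Cc1ccccc1C[C@H]1COC[C@@H]1Cc1ccc(Cl)c(Cl)c1` gives 21000 nM, compound 2 `Fc1ccccc1C[C@H]1COC[C@@H]1Cc1ccc(Cl)c(Cl)c1` gives 51000 nM, and compound 3 `Cc1cccc(C[C@H]2COC[C@@H]2Cc2ccc(Cl)c(Cl)c2)c1` gives 28000 nM. Compound 3 holds no clear rank among the three. Both a 1.3-fold higher number from compound 1 to compound 3 (0.12 log units; within the scatter) and a 1.8-fold lower number from compound 2 to compound 3 (0.26 log units; within the scatter) lie within the scatter, whereas a 2.4-fold higher number from compound 1 to compound 2 (0.39 log units; beyond the scatter) lies beyond it.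

The next compound is compound 4 `Fc1cccc(C[C@H]2COC[C@@H]2Cc2ccc(Cl)c(Cl)c2)c1`, with the change (fluoro in place of methyl on an aromatic carbon). This places fluoro in place of methyl on an aromatic carbon, meta to a large group, turning 3-methylphenyl into 3-fluorophenyl. The only measured case of the same exchange is the modest step of a 2.4-fold higher number from compound 1 to compound 2 (0.39 log units; beyond the scatter), and it is a single precedent from a different substitution place. The two steps within the scatter involve other changes and add little. A modest rise in this assay is therefore expected, possibly no larger than the scatter. The expected change is a 2.0-fold higher number from compound 3 to compound 4 (0.29 log units; within the scatter). For compound 4 the estimated value is 55000 nM, with an expected range from 30000 nM to 100000 nM.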

Compound 4, half-maximal effective concentration: 20000 nM
For compound 4 the middle estimate is 2.8-fold (0.44 log units) above the measured one; measured number below the stated range.
By their numbers in this assay, from the lowest: compounds 4, 1, 3 and 2 (each within the scatter of the next, the first and the last beyond it).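

Turning 3-methylphenyl into 3-fluorophenyl in this assay gives a 1.4-fold lower number from compound 3 to compound 4 (0.15 log units; within the scatter), so the effect of fluoro in place of methyl seen with the 2-methylphenyl group does not carry over to this place: the same change on two cores in this assay, a 2.4-fold higher number (0.39 log units; beyond the scatter) from compound 1 to compound 2 and a 1.4-fold lower number (0.15 log units; within the scatter) from compound 3 to compound 4, 3.4-fold (0.53 log units) apart, beyond the scatter of two such steps The place of the fluoro matters more than that of the methyl, since 3-fluorophenyl in place of 2-fluorophenyl gives a 2.6-fold lower number from compound 2 to compound 4 (0.41 log units; beyond the scatter), whereas the matching methyl pair gives a 1.3-fold higher number from compound 1 to compound 3 (0.12 log units; within the scatter). 3-Fluorophenyl in place of 2-methylphenyl gives a 1.1-fold lower number from compound 1 to compound 4 (0.02 log units; within the scatter), which leaves compound 2 apart from both compound 1 and compound 4.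

Going by these compounds, with only methyl and fluoro compared at these two places, it remains open whether the step to compound 2 is particular to the 2-fluorophenyl group. On these data alone, how a methoxy group or an amine on this aromatic carbon would read in this assay also stays unknown.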